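Swapping the aryl group on the sulfonyl in an amidine series

The source may report more compounds than this note shows. Statements on the series, on what has been measured and on what is new or still open speak of the compounds shown alone.

Measured so far:
compound 1 `N=C(N)c1cccc(CN2CC[C@H](NS(=O)(=O)c3ccc4ccncc4c3)C2=O)c1`: > 2900 nM
compound 2 `N=C(N)c1cccc(CN2CC[C@H](NS(=O)(=O)c3ccc4cccnc4c3)C2=O)c1`: > 2900 nM

Compounds 1 and 2 share one core and differ only in the aromatic group attached to the sulfonyl sulfur. In an assay on isolated protein for binding affinity to serine protease 1 (Homo sapiens) (on this read-out higher numbers stand for weaker inhibition and lower numbers for stronger inhibition), compound 1 gives > 2900 nM, which is a limit of the assay and not a number. In this assay compound 2 gives > 2900 nM, again a limit rather than a measured number. The step from compound 1 to compound 2 is therefore a step that the two limits leave unreadable from compound 1 to compound 2. Compound 2 thus stands only at a limit, with no numeric value to anchor it.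

Compound 3 `N=C(N)c1cccc(CN2CC[C@H](NS(=O)(=O)c3cc4nc(Cl)ccc4s3)C2=O)c1` differs from compound 2 by a group of 10 heavy atoms (7 carbon, 1 nitrogen, 1 sulfur, 1 chlorine; one five-membered aromatic ring with 1 hetero atom, one six-membered aromatic ring with 1 hetero atom) in place of a group of 10 heavy atoms (9 carbon, 1 nitrogen; one six-membered aromatic ring of carbon only, one six-membered aromatic ring with 1 hetero atom), on a sulfonyl sulfur. Going by the values given here, the single measured step is the one that bears on this change, and its size is not readable. Among the compounds with values here, because the limit of > 2900 nM in this assay, at which 2 of the 2 values shown sit, holds both measured values, no step of any size can be derived from them.

The step from compound 2 to compound 3 is expected to be a step that the limit leaves unreadable from compound 2 to compound 3, and a limit is the most likely outcome. Compound 3 is estimated at 5000 nM, with a range from 800 nM to 30000 nM.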

Compound 3, inhibition constant: > 2900 nM
Compound 3: no number, only a limit (the forecaster's own chance of this, stated with the estimate: 65%); the middle value does not contradict the limit.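

In this assay compound 3 gives > 2900 nM, again a limit of the assay and not a number. No step among compound 1, compound 2 and compound 3 can be read, because every result is a limit: the limit of > 2900 nM in this assay, at which 3 of the 3 values shown sit.

The compounds shown leave open how strongly each one inhibits the protease, and whether changing the aromatic group on the sulfonyl sulfur alters that inhibition.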